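The source may report more compounds than this note shows. Statements on the series, on what has been measured and on what is new or still open speak of the compounds shown alone.

Compound 1 `CCN(c1cc2oc(-c3ccc(F)cc3)c(C(=O)NC)c2cc1-c1cc(F)c(OC)c(C(=O)NC2(c3ncccn3)CC2)c1)S(C)(=O)=O` is one of two compounds with a number in an ADME assay for permeability, using PAMPA, at pH 7.4; a higher number here means that the compound crosses the layer faster, a lower number that the compound crosses the layer more slowly. In this assay, among the compounds with values here, compound 1 gives 659 nm/s, and the only other measured compound, compound 2 `CCN(c1cc2oc(-c3ccc(F)cc3)c(C(=O)NC)c2cc1-c1cc(C)c(OC)c(C(=O)NC2(c3ncccn3)CC2)c1)S(C)(=O)=O`, gives 409 nm/s. Within the data shown here, the single step that connects them, a 1.6-fold lower number from compound 1 to compound 2 (0.21 log units; within the scatter), is a change of methyl in place of fluoro on an aromatic carbon, and it stays inside the usual spread of the measurement.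

Compound 3 `CCN(c1cc2oc(-c3ccc(F)cc3)c(C(=O)NC)c2cc1-c1cc(F)c(F)c(C(=O)NC2(c3ncccn3)CC2)c1)S(C)(=O)=O` has not yet been measured. It differs from compound 1 by fluoro in place of methoxy on an aromatic carbon. Among the measured compounds shown here, no measured step swaps a methoxy for a fluoro, so nothing here speaks directly to this change; the one step that is known, from compound 1 to compound 2, was small. On that basis a step no larger than the scatter is expected, in either direction, written as a 1.1-fold higher number from compound 1 to compound 3 (0.03 log units; within the scatter). Compound 3 is therefore estimated at 700 nm/s, with a range from 400 nm/s to 1200 nm/s.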

Compound 3, apparent permeability: 731 nm/s
Estimate against measurement, compound 3: 1.0-fold (0.02 log units) below; low and high end bracket the measured number.
By their numbers in this assay, from the lowest: compounds 2, 1 and 3 (each within the scatter of the next).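

At the place ortho to a (1-(pyrimidin-2-yl)cyclopropyl)carbamoyl group and ortho to a fluoro group, fluoro in place of methoxy gives a 1.1-fold higher number from compound 1 to compound 3 (0.05 log units; within the scatter) in this assay. Within the data shown here, this is the first reading at this place, since the earlier step concerned another place on the ring, and it shows that this read-out stays within the scatter even though the hydrogen-bond acceptor counted on the methoxy is lost. Nothing given here offers an explanation for this result.

The compounds shown carry only methoxy or fluoro at this place, so they leave open whether an amine, a carboxylic acid or a longer chain there would give a step beyond the scatter. No compound shown combines the methyl of compound 2 with the fluoro of compound 3, so the outcome of the two changes together also remains open.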